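The compounds below may be only part of what the source reports. "The series", "measured", "known", "first", "only" and "open" are said of these compounds alone.

Of the compounds shown here, three sharing one core have been tested in a functional assay on MDA-MB-468 cells (Homo sapiens) for cytotoxicity, read by trypan blue exclusion, with a stated time of 48 h; a higher number here means a weaker inhibitor, a lower number a stronger inhibitor. Compound 1 `O=C(COc1ccccc1)Nc1nc(-c2ccc(Br)cc2)cs1` gives 37100 nM in this assay. Compound 2 `O=C(COc1ccccc1)Nc1nc(-c2ccc(Cl)cc2)cs1` differs from compound 1 by chloro in place of bromo on an aromatic carbon, and in this assay compound 2 gives 44200 nM, a step of a 1.2-fold higher number from compound 1 to compound 2 (0.08 log units; within the scatter). Compound 3 `Cc1ccc(OCC(=O)Nc2nc(-c3ccc(Br)cc3)cs2)cc1` differs from compound 1 by methyl in place of hydrogen on an aromatic carbon, and in this assay compound 3 gives 44500 nM, a step of a 1.2-fold higher number from compound 1 to compound 3 (0.08 log units; within the scatter). All three numbers therefore lie close together.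

Compound 4 `Cc1ccc(OCC(=O)Nc2nc(-c3ccc(Cl)cc3)cs2)cc1` has not yet been measured. It differs from compound 3 by chloro in place of bromo on an aromatic carbon, the same change that was made from compound 1 to compound 2, at a place described in the same way. Since that earlier change produced a step of a 1.2-fold higher number from compound 1 to compound 2 (0.08 log units; within the scatter), a step of similar size is expected here: compound 4 is expected to show a 1.1-fold higher number from compound 3 to compound 4 (0.05 log units; within the scatter) from compound 3. In this assay compound 4 is estimated at 50000 nM, with a likely range from 28000 nM to 90000 nM, resting on the value of compound 3, 44500 nM, and on the small earlier step.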

Compound 4, half-maximal inhibitory concentration: 50100 nM
Estimate against measurement, compound 4: 1.0-fold (0.00 log units) below; the measured number falls inside the stated range.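

In this assay, chloro in place of bromo gives a 1.1-fold higher number from compound 3 to compound 4 (0.05 log units; within the scatter), and the step looks the same on both cores: the same change on two cores in this assay, a 1.2-fold higher number (0.08 log units; within the scatter) from compound 1 to compound 2 and a 1.1-fold higher number (0.05 log units; within the scatter) from compound 3 to compound 4, 1.1-fold (0.02 log units) apart, within the scatter of two such steps. Methyl in place of hydrogen on an aromatic carbon gives a 1.1-fold higher number from compound 2 to compound 4 (0.05 log units; within the scatter), and this change also looks the same on both cores: the same change on two cores in this assay, a 1.2-fold higher number (0.08 log units; within the scatter) from compound 1 to compound 3 and a 1.1-fold higher number (0.05 log units; within the scatter) from compound 2 to compound 4, 1.1-fold (0.02 log units) apart, within the scatter of two such steps. Within the data shown here, this shows that, across these four compounds, neither change moves the number beyond the ordinary scatter of the measurement on either core, but it does not show that a change with a clear effect would carry over from one core to another, since agreement between steps this small is a weak test and rests on only two cores for each change.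

The compounds shown carry only bromo or chloro on one aromatic ring and only hydrogen or methyl on the other. On these data alone, whether an amine, a carboxylic acid or a longer chain at either place would shift the number clearly, and whether such a shift would be the same on both cores, remains open.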